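A few compounds are considered here, and "the series" means these few. Any claim that something is new, unique, unknown or untested is made for them only; others in the source may bear on it.

Measured compounds and their values:

compound 1, `O=[N+]([O-])C1=CNc2nc(-c3ccco3)nn2C1c1ccc(O)cc1O` — 119000 nM
compound 2, `O=[N+]([O-])C1=NNc2ncnn2C1c1ccc(O)c(O)c1O` — 228000 nM
compound 3, `O=[N+]([O-])C1=NNc2ncnn2C1c1ccc(O)cc1O` — 90000 nM

The three compounds were tested in an ADME assay on MDCK cells (Canis lupus familiaris) for cytotoxicity; a higher number here means that more compound is tolerated, a lower number that less compound is tolerated. Compound 2 gives 228000 nM, compound 3 gives 90000 nM, and compound 1 gives 119000 nM. Compound 1 and compound 3 are within the usual scatter of each other, as are compound 1 and compound 2, so no order can be read among them. Compound 3 and compound 2 differ in a single place: hydroxy in place of hydrogen on an aromatic carbon. This change gave a 2.5-fold higher number from compound 3 to compound 2 (0.40 log units; beyond the scatter).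

The same kind of change is now made on compound 1 to give compound 4, `O=[N+]([O-])C1=CNc2nc(-c3ccco3)nn2C1c1c(O)cc(O)cc1O`: hydroxy in place of hydrogen on an aromatic carbon. It is the same kind of change rather than the same one, since the surroundings differ: in the step to compound 2 the new hydroxy is ortho to two hydroxy groups and meta to a large group, whereas in compound 4 it is ortho to a large group and meta to two hydroxy groups. The difference between the two cores of compound 1 and compound 3 is not broken down here.

For compound 4 a step of about a 1.5-fold higher number from compound 1 to compound 4 (0.18 log units; within the scatter) in this assay is expected, a little smaller than the one seen before because the earlier step was a 2.5-fold higher number from compound 3 to compound 2 (0.40 log units; beyond the scatter) and the surroundings of the new group are not the same. Compound 4 is therefore estimated at 180000 nM, with a likely range from 90000 nM to 360000 nM.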

Compound 4, half-maximal cytotoxic concentration: 280000 nM
For compound 4 the middle estimate is 1.6-fold (0.19 log units) below the measured one; the measured number falls inside the stated range.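

In this assay, putting a hydroxy in place of hydrogen on an aromatic carbon gave a 2.4-fold higher number from compound 1 to compound 4 (0.37 log units; beyond the scatter), so the ring with its added hydroxy is tolerated at a higher concentration than the ring without it. Set beside the earlier case, the change carried over from one core to the other with nearly the same size, which suggests that in these two pairs the step did not depend much on the core: the same change on two cores in this assay, a 2.5-fold higher number (0.40 log units; beyond the scatter) from compound 3 to compound 2 and a 2.4-fold higher number (0.37 log units; beyond the scatter) from compound 1 to compound 4, 1.1-fold (0.03 log units) apart, within the scatter of two such steps. Within the data shown here, this rests on only two pairs, however, and the new hydroxy sits in a different place on the ring in each, so the core and the position change together; the data therefore cannot separate their contributions, do not promise the same step on any further core, and do not explain why the number rises.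

The compounds shown leave open whether a different group at this place, such as a methoxy group or an amine, would give a step of similar size. They also leave open whether the step would hold on a core carrying a carboxylic acid, and what the difference between the two cores does by itself.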